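Chloro-to-methyl swap on the aryl ring of compound 1

The source may hold more compounds than are shown below. What is called first, only, known or untested is meant among the compounds shown, and "the series" means these compounds.

Of the compounds shown here, three have been measured in an assay on CHO cells for displacement of a labelled ligand from adenosine receptor A1 (Homo sapiens), read by scintillation counting, with a stated time of 3 h; a lower number here means a stronger inhibitor, a higher number a weaker inhibitor. Compound 1 `Cn1c(-c2cccc(Cl)c2)nc2c(NC3CCCC3)ncnc21` gives 6.5 nM, the lowest number of the set. Compound 2 `CCCn1c(-c2ccccc2)nc2c(NC3CCOC3)ncnc21` gives 25 nM and compound 3 `CCn1c(-c2ccccc2)nc2c(N)ncnc21` gives 31 nM; both gaps to compound 1 lie beyond the usual scatter, so compound 1 stands as the most potent of the three. Among the compounds with values here, no pair among the measured compounds differs in a single place, so no measured step is available to anchor the next change.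

Compound 4 `Cc1cccc(-c2nc3c(NC4CCCC4)ncnc3n2C)c1` is derived from compound 1 by one change: methyl in place of chloro on an aromatic carbon. Both groups carry no donor or acceptor and no charge, and the substituent stays on the same aromatic carbon of the six-membered aromatic ring of carbon only.

Without a measured step of this kind in the series, the expected step in this assay is small, in either direction, and most likely not beyond the scatter; compound 4 is expected to give 9 nM in this assay, within 3 nM to 27 nM. The estimated step from compound 1 to compound 4 is thus a 1.4-fold higher number from compound 1 to compound 4 (0.14 log units; within the scatter), an expectation to be tested against the measured value.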

Compound 4, inhibition constant: 6.2 nM
Estimate against measurement, compound 4: 1.5-fold (0.16 log units) above; the measured number falls inside the stated range.
By their numbers in this assay, from the lowest: compounds 4 and 1 (each within the scatter of the next); then compounds 2 and 3 (each within the scatter of the next).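

The swap of chloro for methyl gives the series its first step in a single place: in this assay it is a 1.0-fold lower number from compound 1 to compound 4 (0.02 log units; within the scatter). Within the data shown here, on this aromatic carbon, meta to a large group, 3-chlorophenyl and 3-methylphenyl therefore cannot be told apart on the core of compound 1, a reading that the earlier compounds, none differing in only one place, could not give. No measured property of either compound bears on this result, so the data give no account of why the two read alike.

Still open, on these data alone, is whether the same carbon tolerates groups of other kinds: an amine, a carboxylic acid or a longer chain in place of chloro could read differently in this assay. Also open, as far as these compounds go, is whether the chloro-to-methyl swap reads the same way at another carbon of this ring or with a different group elsewhere on the shared core.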